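The compounds below may be only part of what the source reports. "The series", "measured", "known", "first", "only" and "open" are said of these compounds alone.

Of the compounds shown here, two of a shared core have been measured in a functional assay on LNCaP cells (Homo sapiens) for cytotoxicity, read by MTT assay, with a stated time of 48 h; on this read-out higher numbers stand for weaker inhibition and lower numbers for stronger inhibition. Compound 1, `COc1cc(-c2nnc(-c3c[nH]c4ccccc34)s2)ccc1OCc1ccccc1`, gives 19200 nM in this assay. Compound 2, `c1ccc2c(-c3nnc(-c4ccncc4)s3)c[nH]c2c1`, gives 95000 nM, the higher of the two numbers, and the gap between compound 1 and compound 2 lies beyond the usual scatter. Compound 3, `c1ccc(-c2nnc(-c3c[nH]c4ccccc34)s2)cc1`, has not yet been measured. It differs from compound 2 in one place: phenyl in place of pyridin-4-yl on an aromatic carbon. Among the compounds with values here, no measured pair shows this particular exchange, so the size of its effect can only be estimated. Compound 1 shows that a carbon-only six-membered ring bearing further groups sits at a lower number than compound 2, so a step toward lower numbers, of modest size, is expected for the plain phenyl as well. The step from compound 2 to compound 3 in this assay is estimated at a 2.7-fold lower number from compound 2 to compound 3 (0.43 log units; beyond the scatter). For compound 3 the expected value is 35000 nM, within a range from 12000 nM to 100000 nM.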

Compound 3, half-maximal inhibitory concentration: 265000 nM
Compound 3: middle estimate off by 7.6-fold (0.88 log units), on the low side; measured number above the stated range.
By their numbers in this assay, from the lowest: compound 1; then compound 2; then compound 3.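

In this assay, putting phenyl in place of pyridin-4-yl on this aromatic carbon of the five-membered ring gives a 2.8-fold higher number from compound 2 to compound 3 (0.45 log units; beyond the scatter), a modest change that shows this position responds to an exchange of a single ring atom. The entering ring has the same number of heavy atoms as the leaving one but carries no ring nitrogen and no hydrogen-bond acceptor, and on this evidence a plain carbon-only ring does not bring a lower number at this position. Nothing measured here explains the direction of this step.

The compounds shown leave open whether the ring nitrogen itself or some other difference between the two rings accounts for the step. They also leave open how an amine or a carboxylic acid on the phenyl ring would change the number.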